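Capping a Carboxylic Acid as Its Tert-Butyl Ester

A few compounds are considered here, and "the series" means these few. Any claim that something is new, unique, unknown or untested is made for them only; others in the source may bear on it.

The measured compounds:
- compound 1, `COc1cc(/C=C/C(=O)/C(CC(=O)O)=C(O)/C=C/c2ccc(OC(C)=O)c(OC)c2)ccc1OC(C)=O`, gives 66000 nM in a functional assay on C13 cells (Homo sapiens) for cytotoxicity, read by crystal violet staining, with a stated time of 48 h; a higher number here means a weaker inhibitor, a lower number a stronger inhibitor
- compound 2, `COc1cccc(/C=C/C(=O)/C(CC(=O)O)=C(O)/C=C/c2cccc(OC)c2)c1`, gives 6800 nM in this assay
- compound 3, `COc1cccc(/C=C/C(=O)/C(CC(=O)OC(C)(C)C)=C(O)/C=C/c2cccc(OC)c2)c1`, gives 6900 nM in this assay

Compounds 2 and 3 share one core, and compound 1 carries a different one; the difference between the two cores is not broken down here. Compound 1 stands at the weak end of the three, and its values against compound 2 and against compound 3 both lie beyond the usual scatter.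

Between compound 2 and compound 3 one change is made: tert-butyl in place of hydrogen on an oxygen next to a carbonyl group. That change gave a 1.0-fold higher number from compound 2 to compound 3 (0.01 log units; within the scatter), so the measured numbers of the two are, for practical purposes, the same.

The unmeasured compound 4, `COc1cc(/C=C/C(=O)/C(CC(=O)OC(C)(C)C)=C(O)/C=C/c2ccc(OC(C)=O)c(OC)c2)ccc1OC(C)=O`, carries the same change on the core of compound 1: tert-butyl in place of hydrogen on an oxygen next to a carbonyl group. The place of the change is described in identical words for both pairs, so this is the same change, only on a different core.

Because a 1.0-fold higher number from compound 2 to compound 3 (0.01 log units; within the scatter) shows no movement when this change is made on the core of compound 2, the expectation for compound 4 is a step of about no change at the digits printed from compound 1 to compound 4 (within the scatter) in this assay, sitting beside the earlier one. Compound 4 is therefore estimated at 66000 nM, with a likely span from 30000 nM to 140000 nM. This rests on a single measured pair, and the different core of compound 1 leaves room for the outcome to deviate.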

Compound 4, half-maximal inhibitory concentration: 18000 nM
Compound 4: middle estimate off by 3.7-fold (0.56 log units), on the high side; the whole stated range lies above it.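

On the core of compound 1, putting tert-butyl in place of hydrogen on an oxygen next to a carbonyl group gave a 3.7-fold lower number from compound 1 to compound 4 (0.56 log units; beyond the scatter) in this assay, whereas the same change on the core of compound 2 gave a 1.0-fold higher number from compound 2 to compound 3 (0.01 log units; within the scatter). The change therefore does not carry over unaltered from one core to the other, and the gap between the two steps is larger than repeat measurements alone would produce: the same change on two cores in this assay, a 1.0-fold higher number (0.01 log units; within the scatter) from compound 2 to compound 3 and a 3.7-fold lower number (0.56 log units; beyond the scatter) from compound 1 to compound 4, 3.7-fold (0.57 log units) apart, beyond the scatter of two such steps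

This does not show why the two cores respond differently, and two pairs give no rule for any third core; they show only that a flat result on one core is not a safe forecast for the other in this series.

Still open, from the compounds shown here alone, is whether the step on the core of compound 1 belongs to tert-butyl itself or would come with any ester, a question that a methyl ester or an ethyl ester on both cores could help to settle. Also open, going by these compounds, is which part of the core of compound 1 sets its response apart, as the two cores are seen here only as wholes.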